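Amino in Place of Isobutyl: Expectation Before Measurement

A few compounds are considered here, and "the series" means these few. Any claim that something is new, unique, unknown or untested is made for them only; others in the source may bear on it.

Measured in an assay on membranes from brain for displacement of a labelled ligand from Neuronal acetylcholine receptor; alpha4/beta2 (Rattus norvegicus); on this read-out higher numbers stand for weaker inhibition and lower numbers for stronger inhibition:
compound 1 `CN1CCC[C@H]1COc1cncc(Cl)c1` gives 0.6 nM;
compound 2 `CCCc1cncc(OC[C@@H]2CCCN2C)c1` gives 0.12 nM;
compound 3 `CC(C)Cc1cncc(OC[C@@H]2CCCN2C)c1` gives 0.21 nM.

Compound 3 stands second highest of these three numbers: its nearest neighbour is compound 2, a gap within the scatter, while the furthest is reached by the step of a 2.9-fold lower number from compound 1 to compound 3 (0.46 log units; beyond the scatter), which lies beyond the scatter.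

Compound 4 `CN1CCC[C@H]1COc1cncc(N)c1` differs from compound 3 by amino in place of isobutyl on an aromatic carbon. Within the data shown here, no measured step brings in an amino group. The steps at this position are a 5.0-fold lower number from compound 1 to compound 2 (0.70 log units; beyond the scatter) and a 2.9-fold lower number from compound 1 to compound 3 (0.46 log units; beyond the scatter), both modest gains on swapping chloro for an alkyl chain, while a 1.8-fold higher number from compound 2 to compound 3 (0.24 log units; within the scatter) lies within the scatter. An amino group is unlike either, so in this assay a modest step toward a higher number is expected. Compound 4 is therefore estimated at 1 nM, between 0.2 nM and 5 nM, meaning an expected step of a 4.8-fold higher number from compound 3 to compound 4 (0.68 log units; beyond the scatter).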

Compound 4, inhibition constant: 0.63 nM
Beside the measured number, compound 4's estimate is 1.6-fold (0.20 log units) above it, and the stated range covers the measured number.
By their numbers in this assay, from the lowest: compounds 2 and 3 (each within the scatter of the next); then compounds 1 and 4 (each within the scatter of the next).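

In this assay, among these compounds, this position accepts amino as readily as chloro, a group no earlier compound carried there (a 1.1-fold higher number from compound 1 to compound 4 (0.02 log units; within the scatter)). Both alkyl chains keep their advantage over amino (a 3.0-fold higher number from compound 3 to compound 4 (0.48 log units; beyond the scatter); a 5.3-fold higher number from compound 2 to compound 4 (0.72 log units; beyond the scatter)), so on these compounds propyl and isobutyl stand apart from both amino and chloro. Nothing measured here explains the size of these steps. On these data alone, whether a dimethylamino group or a carboxylic acid would behave like amino at this position stays open, as does whether a chain longer than isobutyl would hold the low numbers of the alkyl compounds.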